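The source may report more compounds than this note shows. Statements on the series, on what has been measured and on what is new or still open speak of the compounds shown alone.

Measured in an ADME assay (Rattus norvegicus, strain Wistar Han) for pharmacokinetics; a lower number here means that more of the compound stays in the plasma, a higher number that more of the compound sits outside the plasma:

compound 1 `CCn1c(-c2cnc(C)nc2)nc2c(N[C@H]3CCN(C(=O)N4CC(OC)C4)C3)ncnc21`: 0.7 L/kg
compound 2 `CCn1c(-c2cnc(C)nc2)nc2c(N[C@H]3CCN(C(=O)c4cocn4)C3)ncnc21`: 0.6 L/kg
compound 3 `CCn1c(-c2ccc(C(F)(F)F)nc2)nc2c(O[C@H]3CCN(C(=O)N4CC(OC)C4)C3)ncnc21`: 0.2 L/kg

Compound 4 `CCn1c(-c2ccc(C(F)(F)F)nc2)nc2c(O[C@H]3CCN(C(=O)c4cocn4)C3)ncnc21` has not yet been measured. It stands to compound 3 as compound 2 stands to compound 1: 1,3-oxazol-4-yl in place of 3-methoxyazetidin-1-yl on a carbonyl carbon. The earlier instance of this change, (1,3-oxazol-4-yl in place of 3-methoxyazetidin-1-yl on a carbonyl carbon), gave a 1.2-fold lower number from compound 1 to compound 2 (0.07 log units; within the scatter). The two "place" descriptions read the same, so the change is the same one on the second pair.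

The core of compound 3 differs from the core of compound 1 in more than one place; the difference between the two cores is not broken down here. Compound 3 gives the lowest of the three numbers, and its gap to compound 2 and to compound 1 is beyond the scatter in each case.

For compound 4 the step is expected to be about a 1.1-fold lower number from compound 3 to compound 4 (0.05 log units; within the scatter) in this assay, because the earlier instance gave a 1.2-fold lower number from compound 1 to compound 2 (0.07 log units; within the scatter), a step within the scatter. Compound 4 is therefore estimated at 0.18 L/kg, with a range expected from 0.1 L/kg to 0.4 L/kg.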

Compound 4, volume of distribution: 0.3 L/kg
Estimate against measurement, compound 4: 1.7-fold (0.22 log units) below; the measured number falls inside the stated range.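

In this assay, placing 1,3-oxazol-4-yl where 3-methoxyazetidin-1-yl stood on a carbonyl carbon gives a 1.5-fold higher number from compound 3 to compound 4 (0.18 log units; within the scatter). Set beside the earlier instance, the step carries over to the second core without a readable difference: the same change on two cores in this assay, a 1.2-fold lower number (0.07 log units; within the scatter) from compound 1 to compound 2 and a 1.5-fold higher number (0.18 log units; within the scatter) from compound 3 to compound 4, 1.8-fold (0.24 log units) apart, within the scatter of two such steps Across these two pairs, the change therefore leaves the volume of distribution unresolved from the scatter on both cores, and the opposite directions of the two steps cannot be read as a reversal, but two pairs do not show that the same would hold on other cores in the series.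

The core of compound 1 and the core of compound 3 differ in more than one place, so the compounds shown do not separate which of those differences goes with the values seen. Also open, going by these compounds, is how this assay would respond on these cores to other groups on the carbonyl carbon, such as a dimethylamino group or a chain bearing a carboxylic acid.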